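The source may report more compounds than this note shows. Statements on the series, on what has been measured and on what is new or still open speak of the compounds shown alone.

Measured compounds:
compound 1 `COc1ccc(Cn2cc(/C=N\NC(=O)c3c[nH]c4ccccc34)c3cc(OC)ccc32)cc1`, 15000 nM
compound 2 `COc1ccc2c(c1)c(/C=N\NC(=O)c1c[nH]c3ccccc13)cn2Cc1ccc(Cl)cc1`, 8700 nM
compound 3 `COc1ccc(Cn2cc(/C=N\NC(=O)c3c[nH]c4ccc(Br)cc34)c3ccc(F)cc32)cc1`, 31700 nM

Compounds 1 and 2 differ by a single change, (chloro in place of methoxy on an aromatic carbon), and in a functional assay on MCF7 cells (Homo sapiens) for cytotoxicity (a lower number here means a stronger inhibitor, a higher number a weaker inhibitor), the step from compound 1 to compound 2 is a 1.7-fold lower number from compound 1 to compound 2 (0.24 log units; within the scatter). Compound 3 carries a different core; the difference between the two cores and that of compound 1 is not broken down here. Compound 4 `O=C(N/N=C\c1cn(Cc2ccc(Cl)cc2)c2cc(F)ccc12)c1c[nH]c2ccc(Br)cc12` is not yet measured and differs from compound 3 by chloro in place of methoxy on an aromatic carbon, the same change as from compound 1 to compound 2, with the place described in the same words. The change is therefore expected to make a step of about the same small size, a 1.6-fold lower number from compound 3 to compound 4 (0.20 log units; within the scatter), because a 1.7-fold lower number from compound 1 to compound 2 (0.24 log units; within the scatter) stayed within the scatter. Compound 4 is thus estimated to give about 20000 nM in this assay, with a range from 8000 nM to 50000 nM.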

Compound 4, half-maximal inhibitory concentration: 8300 nM
For compound 4 the middle estimate is 2.4-fold (0.38 log units) above the measured one, within the range that was stated.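

Replacing 4-methoxybenzyl with 4-chlorobenzyl on the core of compound 3 gives, in this assay, a 3.8-fold lower number from compound 3 to compound 4 (0.58 log units; beyond the scatter). Set beside the same change on the core of compound 1, this step does not differ from the earlier one by more than the scatter allows: the same change on two cores in this assay, a 1.7-fold lower number (0.24 log units; within the scatter) from compound 1 to compound 2 and a 3.8-fold lower number (0.58 log units; beyond the scatter) from compound 3 to compound 4, 2.2-fold (0.35 log units) apart, within the scatter of two such steps

So the size of the step can be treated as carried from one core to the other, but this rests on only two pairs, one of which stays within the scatter, and it does not show that the change would behave alike on any further core.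

As far as these compounds go, it remains open how an amine or a carboxylic acid in place of the chloro would read in this assay. From the compounds shown here alone, it is also open whether a methyl or a trifluoromethyl there would fit the same picture.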